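Sulfur to Selenium on a Benzylic Chain

The source may hold more compounds than are shown below. What is called first, only, known or untested is meant among the compounds shown, and "the series" means these compounds.

Compound 1 `[SeH]c1nc2ccccc2s1`: > 50000 nM
Compound 2 `CSc1ccc2ccccc2n1`: > 100000 nM
Compound 3 `N#CSCc1ccc(-n2cccc2)cc1`: 8200 nM
Compound 4 `N#C[Se]Cc1ccc(-n2cccc2)cc1`: not yet measured

Of the compounds shown here, three have been measured in a functional assay on MCF7 cells (Homo sapiens) for cytotoxicity, read by MTT assay, with a stated time of 72 h; a lower number here means a stronger inhibitor of growth, a higher number a weaker inhibitor of growth. For compound 1 the result is a limit of the assay, > 50000 nM (the limit of > 50000 nM in this assay, at which 1 of the 3 values shown sits). For compound 2 the result is also a limit, > 100000 nM (the limit of > 100000 nM in this assay, at which 1 of the 3 values shown sits). For the measured compounds named here, compound 3 is the only one with a number, 8200 nM, and so stands alone as the point of reference. Compound 4 differs from compound 3 in one place: a group of 3 heavy atoms (1 carbon, 1 nitrogen, 1 selenium; no ring) in place of a group of 3 heavy atoms (1 carbon, 1 nitrogen, 1 sulfur; no ring), on a saturated chain carbon bound to an aromatic carbon. Going by the values given here, no measured pair shows a change of this kind, so the size of the step rests on expectation alone. The expected step, toward stronger inhibition of growth, is a 2.7-fold lower number from compound 3 to compound 4 (0.44 log units; beyond the scatter). Compound 4 is estimated at 3000 nM, within 800 nM to 15000 nM.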

Compound 4, concentration for 50% growth inhibition: 2400 nM
Compound 4: the middle estimate sits 1.3-fold (0.10 log units) above what was measured; the range from low to high includes it.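

In this assay, the first change measured at this place, selenium in place of sulfur on a saturated chain carbon bound to an aromatic carbon, gives a 3.4-fold lower number from compound 3 to compound 4 (0.53 log units; beyond the scatter) and so moves growth inhibition by a modest step beyond the scatter. A single atom exchange within the group is thus enough to shift the result. Nothing measured here accounts for why the selenium compound gives the lower number.

From the compounds shown here alone, whether a longer chain at this place would preserve the gain stays open. So does whether a carboxylic acid in place of the selenium group would retain any growth inhibition.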